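Two Limits, One New Aryl Group on the Shared Core

The source may report more compounds than this note shows. Statements on the series, on what has been measured and on what is new or still open speak of the compounds shown alone.

Compound 1 `COc1ccccc1-n1nncc1CN1C(=O)C2(C(C#N)=C(N)Oc3c(N)cc4nc5ccccc5nc4c32)c2ccccc21` and compound 2 `Cc1ccc(-n2nncc2CN2C(=O)C3(C(C#N)=C(N)Oc4c(N)cc5nc6ccccc6nc5c43)c3ccccc32)cc1C` share one core and differ only in the group on an aromatic nitrogen. In a functional assay on HCT-116 cells (Homo sapiens) for antiproliferative activity, read by MTT assay, with a stated time of 48 h (on this read-out higher numbers stand for weaker inhibition and lower numbers for stronger inhibition), compound 1 gives > 50000 nM, which is a limit of the assay rather than a number. In this assay compound 2 gives > 50000 nM, again a limit. The step that the two limits leave unreadable from compound 1 to compound 2 therefore cannot be read, since both values sit at the limit of > 50000 nM in this assay, at which 2 of the 2 values shown sit. Compound 3 `CCc1cccc(CC)c1-n1nncc1CN1C(=O)C2(C(C#N)=C(N)Oc3c(N)cc4nc5ccccc5nc4c32)c2ccccc21` carries 2,6-diethylphenyl in place of 3,4-dimethylphenyl on an aromatic nitrogen. Going by the values given here, no measured step shows how this change acts, so compound 3 is expected to stay at the limit, with a number no higher from compound 2 to compound 3 (the limit leaves the size open) meaning no step beyond the scatter. The estimate for compound 3 is 50000 nM, ranging from 20000 nM to 150000 nM.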

Compound 3, half-maximal inhibitory concentration: 37600 nM
For compound 3 the middle estimate is 1.3-fold (0.12 log units) above the measured one; the range from low to high includes it.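

Going by these compounds alone, with 2,6-diethylphenyl on this aromatic nitrogen, compound 3 gives 37600 nM in this assay, the first readable number at this position. The change gives an at least 1.3-fold lower number from compound 2 to compound 3 (0.12 log units; that floor lies within the scatter), and an at least 1.3-fold lower number from compound 1 to compound 3 (0.12 log units; that floor lies within the scatter). Both steps are only floors, and their true sizes cannot be read because the other two values are limits: the limit of > 50000 nM in this assay, at which 2 of the 3 values shown sit.

As far as these compounds go, it remains open whether a phenyl ring carrying an amine or a carboxylic acid, or a longer chain in place of ethyl, would move the number beyond the scatter.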